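A few compounds are considered here, and "the series" means these few. Any claim that something is new, unique, unknown or untested is made for them only; others in the source may bear on it.

Measured compounds:
compound 1, `COCCCNC(=O)Nc1cc2c(Nc3ccc(F)c(Cl)c3)ncnc2cc1O[C@H]1CCOC1`: 4100 nM
compound 2, `O=C(Nc1cc2c(Nc3ccc(F)c(Cl)c3)ncnc2cc1O[C@H]1CCOC1)N1CCC(F)CC1`: 3040 nM

Both numbers come from a functional assay on A-431 cells (Homo sapiens) for antiproliferative activity, read by sulforhodamine B assay, with a stated time of 72 h; on this read-out lower numbers stand for stronger inhibition and higher numbers for weaker inhibition. Compound 1 stands at the higher of the two numbers, but the gap to compound 2 is only a 1.3-fold lower number from compound 1 to compound 2 (0.13 log units; within the scatter), so the two are not separated beyond the scatter.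

Compound 3, `O=C(Nc1cc2c(Nc3ccc(F)c(Cl)c3)ncnc2cc1O[C@H]1CCOC1)N1CCC(F)(F)CC1`, is not yet measured in this assay. It differs from compound 1 by 4,4-difluoropiperidin-1-yl in place of (3-methoxypropyl)amino on a carbonyl carbon. Among the measured compounds shown here, the one measured step that bears on this is the exchange from compound 1 to compound 2, where the same chain left and a 4-fluoropiperidin-1-yl entered, giving a 1.3-fold lower number from compound 1 to compound 2 (0.13 log units; within the scatter). The change to compound 3 goes one step further in the same direction, from one fluorine on the ring to two, and nothing measured here separates those two cases. No step beyond the scatter is therefore expected.

For compound 3 the expected step is a 1.4-fold lower number from compound 1 to compound 3 (0.14 log units; within the scatter). For compound 3 the estimate in this assay is 3000 nM, with a range from 1200 nM to 7500 nM.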

Compound 3, half-maximal inhibitory concentration: 1860 nM
The estimate for compound 3 lay 1.6-fold (0.21 log units) above the measured number; low and high end bracket the measured number.
By their numbers in this assay, from the lowest: compounds 3, 2 and 1 (each within the scatter of the next, the first and the last beyond it).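

In this assay, exchange of the (3-methoxypropyl)amino on the carbonyl carbon now gives a step beyond the scatter, though a modest one: the 4,4-difluoropiperidin-1-yl gives a 2.2-fold lower number from compound 1 to compound 3 (0.34 log units; beyond the scatter) and so separates from the chain, which the 4-fluoropiperidin-1-yl did not do. The second fluorine taken alone, fluoro in place of hydrogen on a saturated ring carbon, gives a 1.6-fold lower number from compound 2 to compound 3 (0.21 log units; within the scatter) and so does not separate the two rings, which means the gain can be read only over the whole exchange. No measurement shown here accounts for this step.

From the compounds shown here alone, the place of an unsubstituted piperidin-1-yl or a morpholin-4-yl on the same carbonyl carbon stays open. So does whether a shorter open chain such as dimethylamino would stand with compound 1 or with compound 3.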